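Prop-1-en-1-yl to Pent-1-en-1-yl on Compound 3

A few compounds are considered here, and "the series" means these few. Any claim that something is new, unique, unknown or untested is made for them only; others in the source may bear on it.

Of the compounds shown here, three sharing one core have been measured in a functional assay on A549 cells (Homo sapiens) for inhibition, read by MTT assay, with a stated time of 72 h; on this read-out lower numbers stand for stronger inhibition and higher numbers for weaker inhibition. Compound 1 `C/C=C\C(=O)Nc1cc(Nc2nc3c(c(-c4cn(C)c5ccccc45)n2)CS(=O)(=O)CC3)c(OC)cc1N(C)CCN(C)C` gives 4260 nM. Compound 2 `C=CC(=O)Nc1cc(Nc2nc3c(c(-c4cn(C)c5ccc(F)cc45)n2)CS(=O)(=O)CC3)c(OC)cc1N(C)CCN(C)C` gives 4640 nM. Compound 3 `C/C=C\C(=O)Nc1cc(Nc2nc3c(c(-c4cn(C)c5ccc(F)cc45)n2)CS(=O)(=O)CC3)c(OC)cc1N(C)CCN(C)C` gives 3990 nM, which lies within the scatter of both others, so the three cannot be ranked.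

Compound 4 `CCC/C=C\C(=O)Nc1cc(Nc2nc3c(c(-c4cn(C)c5ccc(F)cc45)n2)CS(=O)(=O)CC3)c(OC)cc1N(C)CCN(C)C` departs from compound 3 by one change: ethyl in place of hydrogen on a saturated chain carbon bound to a double-bonded chain carbon. This places ethyl in place of hydrogen on a saturated chain carbon bound to a double-bonded chain carbon, so that prop-1-en-1-yl becomes pent-1-en-1-yl.

For the measured compounds named here, two measured steps bear on this. The closer precedent, prop-1-en-1-yl in place of vinyl on a carbonyl carbon, is a 1.2-fold lower number from compound 2 to compound 3 (0.07 log units; within the scatter). The other, fluoro in place of hydrogen on an aromatic carbon, is a 1.1-fold lower number from compound 1 to compound 3 (0.03 log units; within the scatter) and concerns a different part of the molecule. Neither step covers a chain as long as pent-1-en-1-yl, so the evidence is thin and the range must stay wide. Both steps stayed within the scatter, so no shift beyond it is expected in this assay, and no direction can be favoured with confidence. The expected step is a 1.1-fold higher number from compound 3 to compound 4 (0.05 log units; within the scatter). Compound 4 is estimated at 4500 nM, with an expected range from 2200 nM to 9000 nM.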

Compound 4, half-maximal inhibitory concentration: 7570 nM
Estimate against measurement, compound 4: 1.7-fold (0.23 log units) below; low and high end bracket the measured number.
By their numbers in this assay, from the lowest: compounds 3, 1, 2 and 4 (each within the scatter of the next).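

At this position the chain can grow well past the earlier groups without leaving the usual spread of the measurement: with ethyl in place of hydrogen on a saturated chain carbon bound to a double-bonded chain carbon, this assay shows a 1.9-fold higher number from compound 3 to compound 4 (0.28 log units; within the scatter). For the compounds shown here, measured against the shortest group at the same place, the longer chain gives a 1.6-fold higher number from compound 2 to compound 4 (0.21 log units; within the scatter), so vinyl, prop-1-en-1-yl and pent-1-en-1-yl can still not be ranked, now over a wider span of chain than the earlier compounds covered. No measurement shown here accounts for this outcome at the chain.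

The compounds shown leave open whether a longer chain such as hept-1-en-1-yl, or an amine or a carboxylic acid at the far end of the chain, would carry the number in this assay beyond the scatter. They also leave open whether pent-1-en-1-yl would read the same on the core of compound 1, which has hydrogen where compound 4 has fluoro.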